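Isopropyl in Place of Methyl: Whole-Organism Inhibition Expected

The source may report more compounds than this note shows. Statements on the series, on what has been measured and on what is new or still open speak of the compounds shown alone.

Among the three measured compounds, compound 3 `Cc1ccc2[nH]cc(SC3CCN(C)CC3)c2c1` stands second in a functional assay on the whole organism for inhibition, with Mus musculus as the target, at a dose of 30 mg/kg (a lower number here means less inhibition, a higher number more inhibition at the dose given (going by the name of the read-out)), where compound 3 gives 25%. Compound 1 `CN1CCC([S+]([O-])c2c[nH]c3ccc(Cl)cc23)CC1` gives 44%, the highest of the three, and compound 2 `CN1CCC(Sc2c[nH]c3ccc(O)cc23)CC1` gives 9%, the lowest. Within the data shown here, the only step between neighbours differing in one place, a number 16 percentage points higher from compound 2 to compound 3 (beyond the scatter), came with methyl in place of hydroxy on an aromatic carbon. Compound 4 `CC(C)c1ccc2[nH]cc(SC3CCN(C)CC3)c2c1` differs from compound 3 by isopropyl in place of methyl on an aromatic carbon. Among the measured compounds shown here, no measured step covers this change, so the expectation rests on compound 3 alone. The account therefore expects no step beyond the scatter, the estimated step being no change at the digits printed from compound 3 to compound 4 (within the scatter). For compound 4 the estimated value in this assay is 25%, with a range from 5% to 45%.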

Compound 4, a percentage reported as inhibition, in the whole organism at one dose (the size of the read-out at that dose, not a potency): 48%
For compound 4 the middle estimate is 23 percentage points below the measured one; measured number above the stated range.
By their numbers in this assay, from the lowest: compound 2; then compound 3; then compounds 1 and 4 (each within the scatter of the next).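

In this assay, this aromatic carbon keeps responding as the group on it grows: isopropyl in place of methyl gives a number 23 percentage points higher from compound 3 to compound 4 (beyond the scatter) and isopropyl in place of hydroxy gives a number 39 percentage points higher from compound 2 to compound 4 (beyond the scatter) as the larger step. Across hydroxy, methyl and isopropyl at this one place, compounds 2, 3 and 4 thus rise in that order. Nothing measured here accounts for this rise.

As far as these compounds go, whether the rise continues with tert-butyl or a longer chain remains open. So does what an amine or a carboxylic acid at this place would give.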